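This account rests on a few compounds, and the source may have more. Where it says the series, first, only, none or still open, it means among the compounds named here.

Compound 1 `CSc1nn(-c2ccc(S(N)(=O)=O)cc2)c2nc(Nc3ccccc3)n(-c3ccccc3)c(=O)c12`, which in a functional assay on the whole organism (strain Wistar albino) for inhibition, with Rattus norvegicus as the target, read by paw edema, with a stated time of 1 h, at a dose of 25 mg/kg by the oral route (a lower number here means less inhibition, a higher number more inhibition at the dose given (going by the name of the read-out)), gives 68.9%.
Compound 2 `O=c1c2c(Nc3ccc([N+](=O)[O-])cc3)nn(-c3ccccc3)c2nc(Nc2ccccc2)n1-c1ccccc1`, which in this assay gives 29.4%.

Of these two numbers, compound 2 stands lowest, with compound 1 well above it, a gap beyond the usual scatter. Compound 3 `NS(=O)(=O)c1ccc(-n2nc(Nc3ccc([N+](=O)[O-])cc3)c3c(=O)n(-c4ccccc4)c(Nc4ccccc4)nc32)cc1` has not yet been measured. It differs from compound 2 by sulfamoyl in place of hydrogen on an aromatic carbon. Among the compounds with values here, no pair of measured compounds differs by this change alone, so its size cannot be read off directly. The change is expected to raise inhibition by a moderate step, a number 15.6 percentage points higher from compound 2 to compound 3 (beyond the scatter), beyond the scatter. Compound 3 is therefore estimated at 45%, with a likely range from 30% to 62%.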

Compound 3, a percentage reported as inhibition, in the whole organism at one dose (the size of the read-out at that dose, not a potency): 67%
Beside the measured number, compound 3's estimate is 22 percentage points below it, outside the stated range (above it).
By their numbers in this assay, from the lowest: compound 2; then compounds 3 and 1 (each within the scatter of the next).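

In this assay, replacing phenyl with 4-sulfamoylphenyl gives a number 37.6 percentage points higher from compound 2 to compound 3 (beyond the scatter), so this position responds strongly to this change when the (4-nitrophenyl)amino group is present. With sulfamoyl in place, (4-nitrophenyl)amino in place of methylsulfanyl gives a number 1.9 percentage points lower from compound 1 to compound 3 (within the scatter), so that exchange shows no clear effect here. No measurement on hand explains the size of the sulfamoyl step.

As far as these compounds go, it remains open whether a carboxylic acid or an amine in the sulfamoyl position would give a similar rise. It is also unknown whether sulfamoyl gives as large a step when methylsulfanyl is present.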